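Compound 3 to compound 4: quinolin-5-yl for phenyl

This account rests on a few compounds, and the source may have more. Where it says the series, first, only, none or still open, it means among the compounds named here.

In a physicochemical assay for solubility, in phosphate buffer, at pH 7.4 (on this read-out lower numbers stand for lower solubility and higher numbers for higher solubility), compound 1 (`OCC1CCN(c2nccnc2OC2CN(c3nc4ccccc4s3)C2)CC1`) gives 31000 nM and compound 2 (`OCCC1CCN(c2nccnc2OC2CN(c3ccc4ccccc4n3)C2)CC1`) gives 84000 nM. On these data alone, compound 3 (`c1ccc(-c2nccnc2OC2CN(c3ccc4ccccc4n3)C2)cc1`) gives < 1000 nM, which is a limit and not a number, so its exact standing is unknown. The next change leads to compound 4 (`c1ccc2nc(N3CC(Oc4nccnc4-c4cccc5ncccc45)C3)ccc2c1`): quinolin-5-yl in place of phenyl on an aromatic carbon. For the measured compounds named here, the one measured step that bears on it is the large at least 84-fold lower number from compound 2 to compound 3 (1.92 log units; beyond the scatter), but that step removed 4-(2-hydroxyethyl)piperidin-1-yl, so it sets no size for this exchange of one aromatic group for another. The expected step is a number no lower from compound 3 to compound 4 (the limit leaves the size open), with no move beyond the scatter expected in either direction. Compound 4 is estimated at 1000 nM, with an expected range from 300 nM to 4000 nM.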

Compound 4, solubility: 47000 nM
The estimate for compound 4 lay 47-fold (1.67 log units) below the measured number, and the stated range ends below it.
By their numbers in this assay, from the lowest: compounds 1, 4 and 2 (each within the scatter of the next, the first and the last beyond it). At a limit, below all of these: compound 3.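

In this assay, quinolin-5-yl in place of phenyl gives an at least 47-fold higher number from compound 3 to compound 4 (1.67 log units; beyond the scatter). Set against the saturated group, the same position shows a 1.8-fold lower number from compound 2 to compound 4 (0.25 log units; within the scatter), so of the two aromatic groups on this carbon next to the ring nitrogen, only phenyl goes with the low reading. Compound 3 stands at a limit, so the first step has a lower bound only: the limit of < 1000 nM in this assay, at which 1 of the 4 values shown sits.

On these data alone, it remains open whether the ring nitrogen of quinolin-5-yl or its second ring goes with the higher number. Naphthalen-1-yl and pyridin-3-yl at this position would separate the two.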